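The source may report more compounds than this note shows. Statements on the series, on what has been measured and on what is new or still open speak of the compounds shown alone.

In an ADME assay on MT4 cells (Homo sapiens) for cytotoxicity, read by MTT assay (a lower number here means that less compound is tolerated, a higher number that more compound is tolerated), compound 1 `Cc1ccc(N(C(=O)c2cccc([N+](=O)[O-])c2)C(=S)OCCN2C(=O)c3ccccc3C2=O)cc1` gives 100000 nM, compound 2 `Cc1ccc(C(=O)N(C(=S)OCCN2C(=O)c3ccccc3C2=O)c2ccc(C)cc2)cc1` gives 83000 nM and compound 3 `Cc1ccc(N(C(=O)c2cc(F)ccc2F)C(=S)OCCN2C(=O)c3ccccc3C2=O)cc1` gives 62000 nM. Compound 3 therefore stands within the scatter of both other compounds. Compound 4 `Cc1ccc(N(C(=O)c2c(F)cccc2F)C(=S)OCCN2C(=O)c3ccccc3C2=O)cc1` has 2,6-difluorophenyl in place of 2,5-difluorophenyl on a carbonyl carbon. Three measured steps at this same place bear on the change: a 1.2-fold lower number from compound 1 to compound 2 (0.08 log units; within the scatter), a 1.6-fold lower number from compound 1 to compound 3 (0.21 log units; within the scatter) and a 1.3-fold lower number from compound 2 to compound 3 (0.13 log units; within the scatter). Among the compounds with values here, none of them leaves the scatter, although the data contain no direct precedent for the 2,6-difluorophenyl group. No step beyond the scatter is therefore expected in this assay, and no direction can be favoured. The expected change is a 1.1-fold higher number from compound 3 to compound 4 (0.05 log units; within the scatter). Compound 4 is estimated at 70000 nM, with an expected range of 38000 nM to 120000 nM.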

Compound 4, half-maximal cytotoxic concentration: 65000 nM
Compound 4: middle estimate off by 1.1-fold (0.03 log units), on the high side; the range from low to high includes it.
By their numbers in this assay, from the lowest: compounds 3, 4, 2 and 1 (each within the scatter of the next).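

In this assay, 2,6-difluorophenyl in place of 2,5-difluorophenyl on a carbonyl carbon gives a 1.0-fold higher number from compound 3 to compound 4 (0.02 log units; within the scatter), so rearranging the same atoms within the group leaves the number within the scatter. The new group also stays within the scatter of the 4-methylphenyl and 3-nitrophenyl groups, with a 1.3-fold lower number from compound 2 to compound 4 (0.11 log units; within the scatter) and a 1.5-fold lower number from compound 1 to compound 4 (0.19 log units; within the scatter), so all four groups at this position remain indistinguishable. No available data explain why these numbers lie so close together.

From the compounds shown here alone, whether an amine, a carboxylic acid or a longer chain in place of the phenyl ring on this carbonyl carbon would leave the scatter remains open. Going by these compounds, the effect of changes elsewhere on the shared core also remains open.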